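Fluoro to methyl on a potent growth inhibitor

The compounds below may be only part of what the source reports. "The series", "measured", "known", "first", "only" and "open" are said of these compounds alone.

Going by the values given here, in a functional assay on IGROV-1 cells (Homo sapiens) for inhibition (a higher number here means a weaker inhibitor of growth, a lower number a stronger inhibitor of growth), compound 1 `Cc1cc(-c2nc3cccc(F)c3s2)ccc1N` gives 70 nM, the only exact number so far.

Compound 2 `Nc1ccc(-c2nc3ccccc3s2)cc1F` is reported as < 10 nM, which is a limit of the assay and not a number.

Compound 3 `Cc1cc(-c2nc3ccccc3s2)ccc1N` differs from compound 2 in a single place: methyl in place of fluoro on an aromatic carbon. This is methyl in place of fluoro on an aromatic carbon, ortho to an amino group, and the rest of the structure stays the same.

Among the compounds with values here, no measured pair of compounds shows this swap on its own, so the expectation is only a cautious one. One small group replaces another, and no large change in this assay is expected. Any shift would most likely be towards slightly weaker inhibition, or none beyond the scatter. The result for compound 3 may well be a limit too, and the exact number for compound 1 serves as a rough guide to the upper end of the range.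

The expected change a step that the limit leaves unreadable from compound 2 to compound 3 is small. Compound 3 is estimated at 8 nM, with an expected range of 1 nM to 40 nM.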

Compound 3, concentration for 50% growth inhibition: < 10 nM
Compound 3 gave a limit, no number; the forecaster's own chance of this, stated with the estimate: 60%; the middle value is on the limit's open side.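

In this assay, compound 3 is reported as < 10 nM, which is a limit of the assay and not a number. Methyl in place of fluoro at this position, ortho to the amino group, still leaves a compound at that limit, so strong growth inhibition does not depend on the fluoro here, but the size of any change cannot be read because both compounds stop at the same limit: the limit of < 10 nM in this assay, at which 2 of the 3 values shown sit.

Compound 3 also forms a readable pair with compound 1, which has the same methyl: the loss of the second fluoro gives an at least 7.0-fold lower number from compound 1 to compound 3 (0.84 log units; beyond the scatter), so in this one pair the weaker inhibition of compound 1 goes with that second fluoro and not with the methyl.

On these data alone, how far past the limit compound 2 and compound 3 truly lie remains open, and so does whether fluoro and methyl differ at all at this position. As far as these compounds go, it is also open how a chloro, a methoxy or a hydroxyl group would fare at the same position, and whether the effect of the second fluoro would hold in a compound without the methyl.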